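Prodrug Esters: One Carbonate Swap

The source may report more compounds than this note shows. Statements on the series, on what has been measured and on what is new or still open speak of the compounds shown alone.

Measured compounds:
- compound 1 `C[C@@H](O)[C@H]1C(=O)N2C(C(=O)OCOC(=O)OC(C)(C)C)=C(S[C@@H]3CN[C@H](C(=O)Nc4cccc(C(=O)O)c4)C3)[C@H](C)[C@H]12`: 0%
- compound 2 `C[C@@H](O)[C@H]1C(=O)N2C3=C(S[C@@H]4CN[C@@H](C4)C(=O)Nc4cccc(c4)C(=O)OCCCOC3=O)[C@H](C)[C@H]12`: 0%
- compound 3 `Cc1oc(=O)oc1COC(=O)N1C[C@@H]2C[C@H]1C(=O)Nc1cccc(c1)C(=O)OC/C=C\COC(=O)C1=C(S2)[C@H](C)[C@@H]2[C@@H]([C@@H](C)O)C(=O)N12`: 0%

Of the compounds shown here, three have been tested in an ADME assay on a cell-free system (plasma, Rattus norvegicus) for metabolic stability, read by LC-MS, with a stated time of 60 min, at 37 degrees C, tested at 50 uM; a lower number here means that less of the compound is left, a higher number that more of the compound is left. All three share a common core carrying an acid group that has been capped as an ester. In this assay compound 1 gives 0%. Compound 2 gives 0%, and compound 3 gives 0%. Compound 1 therefore stands level with compounds 2 and 3: the gap to compound 2 and the gap to compound 3 both lie within the usual scatter of such measurements, so no order among the three can be read from these numbers. None of the three leaves any measurable amount behind after the stated time.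

The next compound, compound 4 `CCOC(=O)OCOC(=O)C1=C(S[C@@H]2CN[C@H](C(=O)Nc3cccc(C(=O)O)c3)C2)[C@H](C)[C@@H]2[C@@H]([C@@H](C)O)C(=O)N12`, differs from compound 1 in a single place: ethyl in place of tert-butyl on an oxygen next to a carbonyl group. Going by the values given here, no measured pair in this set differs in only one place, so no measured step is available to set the size of this change. The expected step from compound 1 to compound 4 in this assay is therefore none beyond the scatter, as no change at the digits printed from compound 1 to compound 4 (within the scatter).

Compound 4 is estimated to give 0%, with a range from 0% to 10%.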

Compound 4, percent of the compound remaining: 0%
For compound 4 middle estimate and measured number coincide at the digits printed, and the stated range covers the measured number.
By their numbers in this assay, from the lowest: compounds 1, 2, 3 and 4 (each within the scatter of the next).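

Going by these compounds alone, the pair gives the first step in this set between compounds that differ in one place. In this assay, ethyl in place of tert-butyl on an oxygen next to a carbonyl group gives no change at the digits printed from compound 1 to compound 4 (within the scatter), so this position has now been changed directly, and the read-out stays the same. Both compounds sit at the bottom of this scale, where a faster or a slower loss would print the same number, and nothing given here explains the result.

From the compounds shown here alone, whether another group on this oxygen, such as a phenyl ring or a longer chain carrying an amine, would leave any compound behind after the stated time remains open. The compounds shown also leave open how compound 1 and compound 4 would compare after a shorter time, when some of each might still be present.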